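What remains when the aryl group leaves the nitrogen

This account rests on a few compounds, and the source may have more. Where it says the series, first, only, none or still open, it means among the compounds named here.

In a functional assay on HeLa cells (Homo sapiens) for antiproliferative activity, read by MTT assay, with a stated time of 72 h (a higher number here means a weaker inhibitor, a lower number a stronger inhibitor), compound 1 `COc1cccc(N2C(=O)COc3ccc(-c4cnc5ccccc5c4)cc32)c1`, with a 3-methoxyphenyl group on the nitrogen, gives 11400 nM. Compound 3 `O=C1COc2ccc(-c3cnc4ccccc4c3)cc2N1c1ccc(F)cc1`, with 4-fluorophenyl there, gives 38800 nM, the higher of the two actual numbers. Compound 2 `COc1ccc(N2C(=O)COc3ccc(-c4cnc5ccccc5c4)cc32)cc1` reaches only a limit of the assay, > 40000 nM.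

Compound 4 `O=C1COc2ccc(-c3cnc4ccccc4c3)cc2N1` loses the aryl group altogether, with hydrogen now on the amide-type nitrogen in a ring: hydrogen in place of 4-fluorophenyl on an amide-type nitrogen in a ring. Going by the values given here, no measured step removes this group, so the evidence is indirect. The nearest steps only swap one aryl group for another. These are a 3.4-fold higher number from compound 1 to compound 3 (0.53 log units; beyond the scatter) and an at least 3.5-fold higher number from compound 1 to compound 2 (0.54 log units; beyond the scatter), both beyond the scatter, and an at least 1.0-fold lower number from compound 2 to compound 3 (0.01 log units; that floor lies within the scatter), whose floor lies within it. Only compound 1 stands clearly lower, so no gain is expected from losing the aryl group. The expected step is small and within the scatter, a 1.1-fold higher number from compound 3 to compound 4 (0.03 log units; within the scatter). For compound 4 the estimate is 42000 nM, with an expected range of 15000 nM to 90000 nM, and the assay may well report only a limit.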

Compound 4, half-maximal inhibitory concentration: > 40000 nM
Compound 4 gave a limit, no number; the forecaster's own chance of this, stated with the estimate: 60%; the middle value does not contradict the limit.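

In this assay compound 4 gives only a limit, which it shares with compound 2: the limit of > 40000 nM in this assay, at which 2 of the 4 values shown sit.

Replacing the 3-methoxyphenyl group with hydrogen gives an at least 3.5-fold higher number from compound 1 to compound 4 (0.54 log units; beyond the scatter), so the shared core without an aryl group does not match the result of compound 1. Replacing 4-fluorophenyl with hydrogen gives an at least 1.0-fold higher number from compound 3 to compound 4 (0.01 log units; that floor lies within the scatter), a floor that shows no readable change, and the step from the 4-methoxyphenyl compound cannot be read because both ends are limits.

Going by these compounds, because compound 4 gives no actual number, how far it lies past the limit stays unknown. Also open, on these data alone, is whether a small methyl group, a benzyl group or a chain ending in an amine on this nitrogen would bring the number down towards that of compound 1.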